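A few compounds are considered here, and "the series" means these few. Any claim that something is new, unique, unknown or untested is made for them only; others in the source may bear on it.

Measured in a functional assay on the whole organism (stomach) for inhibition, with Rattus norvegicus as the target, at a dose of 80 mg/kg; on this read-out higher numbers stand for more inhibition at the one dose given (going by the name of the read-out) and lower numbers for less inhibition:
compound 1 `CC(C)c1ccc(-c2cc(=O)c3cc(C(=O)O)ccc3o2)cc1` gives 19%
compound 2 `COc1ccc(-c2cc(=O)c3cc(C(=O)O)ccc3o2)cc1` gives 13%
compound 3 `CC(C)c1ccc(-c2oc3ccc(C(=O)O)cc3c(=O)c2O)cc1` gives 24%

The change methoxy in place of isopropyl on an aromatic carbon made a step of a number 6 percentage points lower from compound 1 to compound 2 (within the scatter) in this assay. The cores of compound 1 and compound 3 differ by hydroxy in place of hydrogen on an aromatic carbon, with a step of a number 5 percentage points higher from compound 1 to compound 3 (within the scatter). Between compound 3 and compound 2 no single change is counted; their two values simply show a gap beyond the scatter.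

Compound 4 `COc1ccc(-c2oc3ccc(C(=O)O)cc3c(=O)c2O)cc1` is not yet measured. It carries methoxy in place of isopropyl on an aromatic carbon, the same change as between compound 1 and compound 2, the two place descriptions being identical word for word. A step of a number 6 percentage points lower from compound 3 to compound 4 (within the scatter) is expected in this assay, because the earlier step of a number 6 percentage points lower from compound 1 to compound 2 (within the scatter) stayed within the scatter. Compound 4 is thus estimated at 18%, within 8% to 28%.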

Compound 4, a percentage reported as inhibition, in the whole organism at one dose (the size of the read-out at that dose, not a potency): 24%
The estimate for compound 4 lay 6 percentage points below the measured number; low and high end bracket the measured number.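

In this assay, methoxy in place of isopropyl on an aromatic carbon gives no change at the digits printed from compound 3 to compound 4 (within the scatter), and this agrees with the step on the other core: the same change on two cores in this assay, a number 6 percentage points lower (within the scatter) from compound 1 to compound 2 and no change at the digits printed (within the scatter) from compound 3 to compound 4, 6 percentage points apart, within the scatter of two such steps
Hydroxy in place of hydrogen on an aromatic carbon gives a number 11 percentage points higher from compound 2 to compound 4 (beyond the scatter), and this also agrees with the earlier step: the same change on two cores in this assay, a number 5 percentage points higher (within the scatter) from compound 1 to compound 3 and a number 11 percentage points higher (beyond the scatter) from compound 2 to compound 4, 6 percentage points apart, within the scatter of two such steps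
Each change thus carries between these two cores within the scatter, but two pairs at one dose show neither that this holds for other cores nor how the compounds compare in potency.

The compounds shown leave open how an amine or a longer chain would read in place of isopropyl or methoxy. Also open, as far as these compounds go, is the outcome with an amide in place of the carboxylic acid.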